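The source may report more compounds than this note shows. Statements on the series, on what has been measured and on what is new or still open speak of the compounds shown alone.

For the measured compounds named here, compound 2 `CC(C)(NC(=O)c1cccc2cc(-c3ccc(Cl)cc3)oc12)C(=O)O` is one of three compounds measured in an assay on isolated protein for inhibition of endoplasmic reticulum aminopeptidase 2 (Homo sapiens); on this read-out higher numbers stand for weaker inhibition and lower numbers for stronger inhibition. Compound 2 gives > 30000 nM, which is a limit of the assay rather than a number. Compound 1 `O=C(NC1(C(=O)O)CCCCC1)c1cc(F)cc2cc(-c3ccc(Cl)cc3)oc12` likewise reaches only a limit, > 30000 nM. Compound 3 `O=C(NC1(C(=O)O)CCCCC1)c1cccc2cc(-c3ccc(Cl)cc3)oc12` also sits at a limit, > 30000 nM. Hence a step that the two limits leave unreadable from compound 1 to compound 3 and a step that the two limits leave unreadable from compound 2 to compound 3; all three values share (the limit of > 30000 nM in this assay, at which 3 of the 3 values shown sit). Compound 4 `CC(C)(NC(=O)c1cccc2c(Br)c(-c3ccc(Cl)cc3)oc12)C(=O)O` differs from compound 2 by bromo in place of hydrogen on an aromatic carbon. Going by the values given here, no measured step yields a readable size, so for compound 4 in this assay the expected step is a number no higher from compound 2 to compound 4 (the limit leaves the size open), most likely leaving it at the limit. Compound 4 is therefore estimated at 30000 nM, expected to fall between 8000 nM and 100000 nM.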

Compound 4, half-maximal inhibitory concentration: > 30000 nM
Compound 4 gave a limit, no number; the forecaster's own chance of this, stated with the estimate: 75%; the middle value lies on the limit itself.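

In this assay no step can be read from compound 2 to compound 4, as both compounds sit at a limit: the limit of > 30000 nM in this assay, at which 4 of the 4 values shown sit. The compounds shown leave open how bromo in place of hydrogen affects inhibition, and which features would give a measurable value.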